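Trading One Side Group for Piperidin-4-yl

The source may hold more compounds than are shown below. What is called first, only, known or untested is meant among the compounds shown, and "the series" means these compounds.

Measured so far in an ADME assay on microsomes from liver (Homo sapiens) for metabolic stability, read by LC-MS, tested at 1 uM; on this read-out higher numbers stand for fast clearance and lower numbers for slow clearance
Compound 1 `c1cc([C@H]2CC[C@]3(CC2)OOC2(O3)C3CC4CC(C3)CC2C4)ccc1OC1CCNCC1` gives 15 mL.min-1.g-1
Compound 2 `CS(=O)(=O)N1CCN(CCCOc2ccc([C@H]3CC[C@]4(CC3)OOC3(O4)C4CC5CC(C4)CC3C5)cc2)CC1` gives 68 mL.min-1.g-1

Of the two numbers, the higher belongs to compound 2 at 68 mL.min-1.g-1 and the lower to compound 1 at 15 mL.min-1.g-1 in this read-out, a gap that lies beyond the usual scatter. Compound 3 `c1cc([C@H]2CC[C@]3(CC2)OOC2(O3)C3CC4CC(C3)CC2C4)ccc1OCC1CCNCC1` has not yet been measured. Its structure departs from that of compound 2 as follows: piperidin-4-yl in place of 2-(4-(methylsulfonyl)piperazin-1-yl)ethyl on a saturated chain carbon bound to an oxygen on an aromatic ring in words, piperidin-4-yl in place of 2-(4-(methylsulfonyl)piperazin-1-yl)ethyl on a saturated chain carbon bound to an oxygen on an aromatic ring. The closest measured comparison is compound 1, which also carries a piperidin-4-yl group and gives 15 mL.min-1.g-1 in this assay as its result. Two measured compounds make a thin basis, but slower clearance is expected, with an estimated 3.4-fold lower number from compound 2 to compound 3 (0.53 log units; beyond the scatter) as a change larger than the usual scatter. The estimate for compound 3 is 20 mL.min-1.g-1 with an expected range from 8 mL.min-1.g-1 to 50 mL.min-1.g-1 in this assay.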

Compound 3, intrinsic clearance in microsomes: < 7 mL.min-1.g-1
Compound 3: only a limit was reported; the forecaster's own chance of this, stated with the estimate: 3%; at least 2.8-fold (0.45 log units) between middle value and limit.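

Among these compounds, putting piperidin-4-yl in place of 2-(4-(methylsulfonyl)piperazin-1-yl)ethyl on a saturated chain carbon bound to an oxygen on an aromatic ring gives an at least 9.7-fold lower number from compound 2 to compound 3 (0.98 log units; beyond the scatter) in this assay, the first direct reading of a change at this position. The second step shows that the saturated carbon carrying the piperidine ring also counts, since (piperidin-4-yl)methyl in place of piperidin-4-yl on an oxygen on an aromatic ring gives an at least 2.1-fold lower number from compound 1 to compound 3 (0.33 log units; beyond the scatter), so the two compounds with a piperidine ring are not interchangeable in this read-out. The value of compound 3 in this assay is a limit and not a number: the limit of < 7 mL.min-1.g-1 in this assay, at which 1 of the 3 values shown sits.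

The compounds shown leave open how far the number falls for compound 3, and which part of the departing group accounts for the step, the methylsulfonyl group, the piperazine ring or the ethyl chain. A piperidin-4-yl group capped with methylsulfonyl, a morpholine on the same chain, or a longer chain carrying the piperidin-4-yl group would begin to separate these parts.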